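The compounds below may be only part of what the source reports. "The series", "measured", "known", "first", "only" and "open" are said of these compounds alone.

In a functional assay on SF-268 cells (Homo sapiens) for inhibition, read by sulforhodamine B assay, with a stated time of 48 h, tested at 10 uM (on this read-out lower numbers stand for less inhibition and higher numbers for more inhibition at the one concentration tested (going by the name of the read-out)), compound 2 `CC(=O)c1ccc(-c2cn3ccnc3c(-c3ccc4ncn(C5CCCCC5)c4c3)n2)cc1` gives 5.01%, and compound 1 `c1ccc2c(-c3cn4ccnc4c(-c4ccc5ncn(C6CCCCC6)c5c4)n3)cccc2c1` gives 7.84%; the two lie within the scatter of each other, the step of a number 2.8 percentage points lower from compound 1 to compound 2 (within the scatter) being the only measured one. Compound 3 `Clc1ccc(-c2cn3ccnc3c(-c3ccc4ncn(C5CCCCC5)c4c3)n2)cc1` differs from compound 2 by chloro in place of acetyl on an aromatic carbon. The measured step also exchanged the aryl group on the shared core and stayed within the scatter, so it bears on this change only loosely. For compound 3 the expected step in this assay is a number 1 percentage points higher from compound 2 to compound 3 (within the scatter), nothing beyond the scatter. Compound 3 is therefore estimated at 6%, with a range from -5% to 18%.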

Compound 3, a percentage reported as inhibition, at one concentration (the size of the read-out at that concentration, not a potency): 4.83%
Estimate against measurement, compound 3: 1.2 percentage points above; low and high end bracket the measured number.
By their numbers in this assay, from the lowest: compounds 3, 2 and 1 (each within the scatter of the next).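

In this assay, the step for chloro in place of acetyl, on an aromatic carbon para to a large group, is a number 0.2 percentage points lower from compound 2 to compound 3 (within the scatter) despite the loss of heavy atoms and the hydrogen-bond acceptor. The step for 4-chlorophenyl in place of naphthalen-1-yl is a number 3 percentage points lower from compound 1 to compound 3 (within the scatter), so the three aryl groups shown cannot be told apart in this read-out. Nothing measured here offers an explanation for this. On these data alone, whether an amine or a carboxylic acid at this position would move the number beyond the scatter stays open.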